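Anilide variation on the shared core: towards compound 4

The compounds below may be only part of what the source reports. "The series", "measured", "known", "first", "only" and "open" are said of these compounds alone.

Compound 1 `O=C(CCC(=O)OCCCCCCSc1ccc([N+](=O)[O-])c2nonc12)Nc1ccccc1` carries the shared core with an unsubstituted phenyl on the amide-type nitrogen. Going by the values given here, in a functional assay on A549 cells (Homo sapiens) for inhibition, read by MTT assay, with a stated time of 72 h (a lower number here means a stronger inhibitor, a higher number a weaker inhibitor), compound 1 gives 1960 nM, the lowest of the three numbers measured so far. Compound 2 `COc1ccc(NC(=O)CCC(=O)OCCCCCCSc2ccc([N+](=O)[O-])c3nonc23)cc1` gives 6480 nM in this assay, and compound 3 `COc1ccc(NC(=O)CCC(=O)OCCCCCCSc2ccc([N+](=O)[O-])c3nonc23)cc1OC` gives 3890 nM. Of the two substitutions on this phenyl, a 3.3-fold higher number from compound 1 to compound 2 (0.52 log units; beyond the scatter), while a 2.0-fold higher number from compound 1 to compound 3 (0.30 log units; within the scatter); between the two substituted compounds, a 1.7-fold lower number from compound 2 to compound 3 (0.22 log units; within the scatter).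

Compound 4 `O=C(CCC(=O)OCCCCCCSc1ccc([N+](=O)[O-])c2nonc12)Nc1ccc(F)c(Cl)c1` is the next step from compound 1. The change is 3-chloro-4-fluorophenyl in place of phenyl on an amide-type nitrogen. Among the compounds with values here, no measured step introduces a halogen on this phenyl, so none bears directly on it. What the series does show is that each substitution on this phenyl left compound 1 with the lowest number, once beyond the scatter and once within it. On that basis a modestly higher number is expected for compound 4 in this assay, a 1.5-fold higher number from compound 1 to compound 4 (0.18 log units; within the scatter), though a result within the scatter of compound 1 would not be surprising. Compound 4 is therefore estimated at 3000 nM in this assay, with a range of 1200 nM to 8000 nM.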

Compound 4, half-maximal inhibitory concentration: 3210 nM
Compound 4: the middle estimate sits 1.1-fold (0.03 log units) below what was measured; the range from low to high includes it.
By their numbers in this assay, from the lowest: compounds 1, 4, 3 and 2 (each within the scatter of the next, the first and the last beyond it).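

Working notes on the anilide position. In this assay, the first halogen-bearing phenyl in the series gives a 1.6-fold higher number from compound 1 to compound 4 (0.21 log units; within the scatter), so 3-chloro-4-fluorophenyl cannot be told apart from the unsubstituted phenyl at this amide-type nitrogen, unlike 4-methoxyphenyl, whose step from compound 1 is printed as beyond the scatter. Set against the methoxy-bearing anilides, the same change gives a 1.2-fold lower number from compound 3 to compound 4 (0.08 log units; within the scatter) and a 2.0-fold lower number from compound 2 to compound 4 (0.31 log units; beyond the scatter), so the halogen pair cannot be told apart from 3,4-dimethoxyphenyl and separates only from 4-methoxyphenyl, by a modest step. Nothing at hand accounts for any of these steps.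

The compounds shown leave open how a phenyl carrying chlorine alone or fluorine alone would read, so the contribution of each halogen to the step from compound 1 cannot be separated. Also open, going by these compounds, is how this position would respond to an amine or a carboxylic acid on the phenyl, groups that lie outside the methoxy and halogen substituents seen so far.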